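Swapping one aryl group at the assay limit

The source may hold more compounds than are shown below. What is called first, only, known or untested is meant among the compounds shown, and "the series" means these compounds.

Compound 1 `O=C(Nc1ccc(Br)cc1)Nc1ccc(Nc2ncnc3[nH]ncc23)cc1`: > 10000 nM (a limit)
Compound 2 `COc1cccc(NC(=O)Nc2ccc(Oc3ncnc4[nH]ncc34)cc2)c1`: > 10000 nM (a limit)

In a functional assay on HeLa cells (Homo sapiens) for inhibition, read by MTT assay, with a stated time of 72 h (a higher number here means a weaker inhibitor, a lower number a stronger inhibitor), compound 2 gives > 10000 nM, which is a limit of the assay and not a number. Both measured compounds stand at the limit of > 10000 nM in this assay, at which 2 of the 2 values shown sit. Compound 3 `Cc1cccc(NC(=O)Nc2ccc(Oc3ncnc4[nH]ncc34)cc2)c1C` differs from compound 2 in one place: 2,3-dimethylphenyl in place of 3-methoxyphenyl on an amide-type nitrogen. In short, 2,3-dimethylphenyl sits in place of 3-methoxyphenyl on an amide-type nitrogen. Within the data shown here, no measured step exists to guide the expectation, so it rests on the limit of compound 2 alone: no change beyond the usual scatter, in either direction. The expected size is a number no higher from compound 2 to compound 3 (the limit leaves the size open). For compound 3 the estimated value is 10000 nM, with an expected range of 3000 nM to 30000 nM.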

Compound 3, half-maximal inhibitory concentration: > 10000 nM
Compound 3 was reported as a limit; the forecaster's own chance of this, stated with the estimate: 75%; the middle value sits exactly at the limit.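

No step can be read from compound 2 to compound 3, since both stand at a limit and not at a number: the limit of > 10000 nM in this assay, at which 3 of the 3 values shown sit. The compounds shown leave open whether 2,3-dimethylphenyl and 3-methoxyphenyl differ at all in this assay, and which structure would give a readable value.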